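The source may report more compounds than this note shows. Statements on the series, on what has been measured and on what is new or still open speak of the compounds shown alone.

Values in a functional assay with Rattus norvegicus as the target; on this read-out higher numbers stand for weaker inhibition and lower numbers for stronger inhibition:

- Compound 1 `CC1(C)C[C@@H](c2cccc[n+]2[O-])c2cc(C#N)ccc2O1`: 75 nM
- Compound 2 `CC1(C)C[C@H](c2cccc[n+]2[O-])c2cc(C#N)ccc2O1`: 210 nM
- Compound 3 `CC1(C)Oc2ccc(C#N)cc2[C@H](c2cccc[n+]2[O-])[C@H]1O`: 1200 nM

Compound 3 has the highest number of the three. Its value of 1200 nM lies above those of both other compounds, and a 16-fold higher number from compound 1 to compound 3 (1.20 log units; beyond the scatter) accompanies hydroxy in place of hydrogen on a saturated ring carbon. Its unmeasured counterpart is compound 4 `CC1(C)Oc2ccc(C#N)cc2[C@@H](c2cccc[n+]2[O-])[C@@H]1O`, and the change is the two compounds have the same atoms and bonds and differ only in configuration as drawn: 2 of 2 stereo elements differ (all stereocentres are inverted: mirror images); a stereocentre at a saturated ring carbon is drawn R in compound 3 and S in compound 4; a stereocentre at a saturated ring carbon is drawn R in compound 3 and S in compound 4. Both compounds carry the hydroxy, so that large step gives no direct measure of the inversion.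

For the measured compounds named here, the closest precedent is a 2.8-fold higher number from compound 1 to compound 2 (0.45 log units; beyond the scatter), a modest step that can be traced to the fact that compounds 1 and 2 differ only in the configuration as drawn. It inverts only one stereocentre, whereas the mirror-image pair inverts both, so a step of similar or somewhat larger size is expected in this assay, towards a higher number. The estimated step is a 2.8-fold higher number from compound 3 to compound 4 (0.45 log units; beyond the scatter). For compound 4, the expected value is 3400 nM, with an estimated range from 1100 nM to 12000 nM.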

Compound 4, half-maximal inhibitory concentration: 100 nM
Estimate against measurement, compound 4: 34-fold (1.53 log units) above; the whole stated range lies above it.
By their numbers in this assay, from the lowest: compounds 1 and 4 (each within the scatter of the next); then compound 2; then compound 3.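

The configuration of the ring carbons carries more weight once the hydroxy is present, and its direction changes: in this assay the mirror-image pair gives a 12-fold lower number from compound 3 to compound 4 (1.08 log units; beyond the scatter), whereas the single inversion without the hydroxy went towards a higher number. The hydroxy also has no single effect of its own, as it gives a 2.1-fold lower number from compound 2 to compound 4 (0.32 log units; beyond the scatter), opposite in direction to its step on the core of compound 1. Its effect in this assay therefore depends on the configuration of the core that carries it: the same change on two cores in this assay, a 16-fold higher number (1.20 log units; beyond the scatter) from compound 1 to compound 3 and a 2.1-fold lower number (0.32 log units; beyond the scatter) from compound 2 to compound 4, 34-fold (1.53 log units) apart, beyond the scatter of two such steps.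

The compounds shown leave open how much each of the two stereocentres contributes, as no stereoisomer of compound 3 with only one centre inverted is among them. Also open, going by these compounds, is whether a methoxy or an amine in place of the hydroxy would depend on configuration in the same way.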